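From piperidin-4-yl to a larger ring group

The compounds below may be only part of what the source reports. "The series", "measured", "known", "first", "only" and "open" are said of these compounds alone.

Measured in an ADME assay on microsomes from liver (Mus musculus) for metabolic stability, read by LC-MS, with a stated time of 10 min, tested at 0.5 uM; a lower number here means that less of the compound is left, a higher number that more of the compound is left
compound 1 `c1ccc2c(c1)CN[C@@H](CN(CC1CCNCC1)[C@H]1CCCc3cccnc31)C2` gives 13%
compound 2 `CN1CCN(CCCN(C[C@H]2Cc3ccccc3CN2C)[C@H]2CCCc3cccnc32)CC1` gives 43%

Compound 1 stands lowest of these two numbers, and the gap up to compound 2 lies beyond the usual scatter. Compared with compound 1, compound 3 `NC(=O)N1CCN(CCCN(C[C@H]2Cc3ccccc3CN2)[C@H]2CCCc3cccnc32)CC1` carries a group of 11 heavy atoms in place of piperidin-4-yl, on a saturated chain carbon bound to an amine nitrogen (a group of 11 heavy atoms (7 carbon, 3 nitrogen, 1 oxygen; one six-membered non-aromatic ring with 2 hetero atoms) in place of a group of 6 heavy atoms (5 carbon, 1 nitrogen; one six-membered non-aromatic ring with 1 hetero atom), on a saturated chain carbon bound to an amine nitrogen). Among the compounds with values here, no measured pair shows what such a swap does, so any forecast is uncertain. Compound 1 sits low at 13% and compound 2 reaches 43%, so there is room to rise. The expected change is upward and beyond the scatter, with an estimated step (a number 20 percentage points higher from compound 1 to compound 3 (beyond the scatter)) in this assay of moderate size. Compound 3 is expected to give about 33% (estimated range 15% to 58%) in this test.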

Compound 3, percent of the compound remaining: 42%
Compound 3: the middle estimate sits 9 percentage points below what was measured; measured number inside the range.
By their numbers in this assay, from the lowest: compound 1; then compounds 3 and 2 (each within the scatter of the next).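

The swap of piperidin-4-yl for the group of 11 heavy atoms, on a saturated chain carbon bound to an amine nitrogen, gives in this assay a clear rise: a number 29 percentage points higher from compound 1 to compound 3 (beyond the scatter). Within the data shown here, the earlier compounds offered no matched pair, so this is the first direct sign that the number in this test responds to a change at this place. No measurement explains the rise, and this single step cannot separate the effect of the larger size from that of the added ring nitrogen or the double bond outside aromatic rings.

On these data alone, it remains open whether a small dimethylamino group or a carboxylic acid at this place would move the number in the same direction. As far as these compounds go, it is also open whether the same swap gives a similar step on a different core.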